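Chloro on the fused core: from compound 3 to compound 4

A few compounds are considered here, and "the series" means these few. Any claim that something is new, unique, unknown or untested is made for them only; others in the source may bear on it.

Working notes on the arylpiperazine propylamine series. All three measured members share the dimethylamide and the propyl linker and differ in the aryl ring on the piperazine and in the core that carries the amide. Compound 1 `CC(C)c1ccccc1N1CCN(CCCNc2ncccc2C(=O)N(C)C)CC1` gives 0.398 nM in a functional assay for antagonist activity at Alpha-1A adrenergic receptor (Oryctolagus cuniculus); on this read-out higher numbers stand for weaker binding and lower numbers for tighter binding. Compound 2 `CN(C)C(=O)c1cnc2ccccc2c1NCCCN1CCN(c2ccccc2OCC(F)(F)F)CC1` gives 3.98 nM in this assay. Compound 3 `COc1cc(F)ccc1N1CCN(CCCNc2c(C(=O)N(C)C)c[nH]c3ccn[n+]2-3)CC1` gives 0.631 nM in this assay. Among these three numbers compound 3 holds the second highest; its value and that of compound 1 lie within the scatter of each other, so no order between the two is claimed, while the number of compound 2 stands beyond the scatter above both.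

Compound 4 `COc1cc(F)ccc1N1CCN(CCCNc2c(C(=O)N(C)C)c[nH]c3c(Cl)cn[n+]2-3)CC1` is not yet measured. It differs from compound 3 in a single place: chloro in place of hydrogen on an aromatic carbon. Going by the values given here, no pair of measured compounds shows a step of this kind, so there is no direct comparison to lean on. The change is confined to the core and leaves the arylpiperazine and the amide untouched. The step expected here, a 1.1-fold lower number from compound 3 to compound 4 (0.02 log units; within the scatter), is small and may fall either way within the scatter. Compound 4 is therefore estimated at 0.6 nM in this assay, with a range from 0.2 nM to 2 nM.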

Compound 4, dissociation constant: 0.794 nM
The estimate for compound 4 lay 1.3-fold (0.12 log units) below the measured number; the range from low to high includes it.
By their numbers in this assay, from the lowest: compounds 1, 3 and 4 (each within the scatter of the next); then compound 2.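

Chloro in place of hydrogen on an aromatic carbon of the five-membered aromatic ring with 2 nitrogen, two ring bonds from the ring nitrogen, gives a 1.3-fold higher number from compound 3 to compound 4 (0.10 log units; within the scatter) in this assay and so leaves the two compounds indistinguishable on this read-out. Going by these compounds alone, this is the first pair that differs in one place only, and it shows that this carbon of the core can carry a chlorine atom with no difference beyond the scatter, while the arylpiperazine and the dimethylamide stay fixed. The data at hand give no reason for this outcome and say nothing on what the chloro does here.

Going by these compounds, one substituent on one carbon marks no limit for the position, so it remains open whether a nitrile, an amine or a carboxylic acid on this same carbon would also stay within the scatter of compound 3. Within the data shown here, a single pair also leaves open whether the chloro step would read the same with a different aryl ring on the piperazine, such as the one carried by compound 2.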